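The source may hold more compounds than are shown below. What is called first, only, known or untested is meant among the compounds shown, and "the series" means these compounds.

Measured compounds:
compound 1 `COc1ccc(/C=C/C(=O)CC(C)=O)cc1OC`, 8200 nM
compound 2 `Cc1cc(/C=C/c2ccc(O)c(O)c2)[nH]n1`, 33100 nM
compound 3 `CC(=O)CC(=O)/C=C/c1ccc(O)cc1`, 8800 nM

All three numbers come from a functional assay on DU-145 cells (Homo sapiens) for cytotoxicity, read by MTT assay, with a stated time of 72 h; on this read-out lower numbers stand for stronger inhibition and higher numbers for weaker inhibition. Compound 1 has the lowest number of the three, yet compound 3 sits within the scatter of it, so the two cannot be ordered; only compound 2 lies beyond the scatter, at a higher number. Compound 4 `COc1ccc(/C=C/c2cc(C)no2)cc1OC` has not yet been measured. It differs from compound 1 in one place: 3-methyl-1,2-oxazol-5-yl in place of (2-oxopropyl)carbonyl on a double-bonded chain carbon bound to a double-bonded chain carbon. Among the measured compounds shown here, no measured pair shows the effect of such a change, and the measured set gives little guidance, since compound 2 gives 33100 nM with a quite different build. The step is expected to run toward a higher number and to exceed the scatter: a 2.4-fold higher number from compound 1 to compound 4 (0.39 log units; beyond the scatter). Compound 4 is estimated at 20000 nM, with a range of 5000 nM to 60000 nM.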

Compound 4, half-maximal inhibitory concentration: > 100000 nM
Compound 4: a limit, no number; the forecaster's own chance of this, stated with the estimate: 20%; middle value at least 5.0-fold (0.69 log units) from the limit.
By their numbers in this assay, from the lowest: compounds 1 and 3 (each within the scatter of the next); then compound 2. At a limit, above all of these: compound 4.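

For compound 4, > 100000 nM in this assay is a limit of the assay and not a number. Placing 3-methyl-1,2-oxazol-5-yl instead of (2-oxopropyl)carbonyl on this chain carbon gives an at least 12-fold higher number from compound 1 to compound 4 (1.08 log units; beyond the scatter), so this position is sensitive to this change. The two groups have the same counts of heavy atoms, hydrogen-bond donors and hydrogen-bond acceptors, so those counts alone do not account for the step. The compounds shown leave open whether a carboxylic acid or an amide at this place would stay near compound 1, and whether the same change on the core of compound 3 would run the same way.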